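Triazole-side substituent and tolerance in the shared core

The source may report more compounds than this note shows. Statements on the series, on what has been measured and on what is new or still open speak of the compounds shown alone.

Compound 3 `Cc1cc(C)c(Oc2cc(Nc3ccc(C#N)cc3)ncc2C(=O)NCc2cn(CCC#N)nn2)c(C)c1` carries cyanomethyl on a saturated chain carbon bound to an aromatic nitrogen. In an ADME assay on MT4 cells (Homo sapiens) for cytotoxicity, read by MTT assay, with a stated time of 5 days (a higher number here means that more compound is tolerated, a lower number that less compound is tolerated), compound 3 gives 40200 nM, the highest of the two plain numbers shown. Compound 1 `COC(=O)Cn1cc(CNC(=O)c2cnc(Nc3ccc(C#N)cc3)cc2Oc2c(C)cc(C)cc2C)nn1` gives 13800 nM. Compound 2 `Cc1cc(C)c(Oc2cc(Nc3ccc(C#N)cc3)ncc2C(=O)NCc2cn(Cc3cccc(F)c3)nn2)c(C)c1` reaches only a limit of this assay, >= 204000 nM (the limit of >= 204000 nM in this assay, at which 1 of the 3 values shown sits). The step of a 2.9-fold higher number from compound 1 to compound 3 (0.46 log units; beyond the scatter) was modest, the step of an at least 14-fold higher number from compound 1 to compound 2 (1.16 log units; beyond the scatter) large, and the step of an at least 5.0-fold lower number from compound 2 to compound 3 (0.70 log units; beyond the scatter) also beyond the scatter. Compound 4 `Cc1cc(C)c(Oc2cc(Nc3ccc(C#N)cc3)ncc2C(=O)NCc2cn(CC(=O)N3CCCC3)nn2)c(C)c1` differs from compound 3 in that ((pyrrolidin-1-yl)carbonyl in place of cyanomethyl on a saturated chain carbon bound to an aromatic nitrogen). For the measured compounds named here, every change at this position so far has shifted the number beyond the scatter, so a shift is expected here too, with the direction uncertain. Compound 4 is expected to give 60000 nM, range 20000 nM to 200000 nM. The step of a 1.5-fold higher number from compound 3 to compound 4 (0.17 log units; within the scatter) is thus estimated as modest and upward.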

Compound 4, half-maximal cytotoxic concentration: 58100 nM
The estimate for compound 4 lay 1.0-fold (0.01 log units) above the measured number, and the stated range covers the measured number.
By their numbers in this assay, from the lowest: compound 1; then compounds 3 and 4 (each within the scatter of the next). At a limit, above all of these: compound 2.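

In this assay, unlike every earlier step at this position, a 1.4-fold higher number from compound 3 to compound 4 (0.16 log units; within the scatter) stays within the scatter, so exchanging cyanomethyl for (pyrrolidin-1-yl)carbonyl leaves the two numbers indistinguishable. With pyrrolidin-1-yl in place of methoxy on a carbonyl carbon, a 4.2-fold higher number from compound 1 to compound 4 (0.62 log units; beyond the scatter) lies beyond the scatter, and an at least 3.5-fold lower number from compound 2 to compound 4 (0.54 log units; beyond the scatter) also lies beyond it. Compound 2 remains a limit: (the limit of >= 204000 nM in this assay, at which 1 of the 4 values shown sits).

As far as these compounds go, how an amine, a carboxylic acid or a longer chain on this carbon would read remains open. From the compounds shown here alone, the actual number for compound 2 also remains open.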